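This account rests on a few compounds, and the source may have more. Where it says the series, first, only, none or still open, it means among the compounds named here.

Measured compounds:
- compound 1 `Cc1cc(-c2nnc(Sc3c(F)cc(C(=O)NO)cc3F)n2C)nn1C` — 6 nM
- compound 2 `Nc1ccc(-c2nnn(Cc3ccc(C(=O)NO)cc3)n2)cc1` — 1 nM
- compound 3 `Cc1cc(-c2nnc(Sc3ccc(C(=O)NO)c(F)c3)n2C)nn1C` — 2240 nM

In an assay on Sf9 cells for inhibition of protein deacetylase HDAC6 (Homo sapiens), read by fluorescence (on this read-out higher numbers stand for weaker inhibition and lower numbers for stronger inhibition), compound 2 gives the lowest number of the three. Compound 1 stands a gap beyond the scatter from it, and compound 3 far beyond. Within the data shown here, no two measured compounds differ in one place, so no step size is known from the series itself.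

Compound 4 `O=C(NO)c1ccc(Cn2nnc(-c3ccccc3)n2)cc1` is not yet measured. Its difference from compound 2:
hydrogen in place of amino on an aromatic carbon

Among the measured compounds shown here, nothing measured so far resembles this change. For the measured compounds named here, with no comparable step to draw on, the expectation for compound 4 is a small loss, probably close to the scatter, worded as an estimate of a 3.0-fold higher number from compound 2 to compound 4 (0.48 log units; beyond the scatter). Compound 4 is therefore expected at 3 nM, within 0.8 nM to 12 nM.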

Compound 4, half-maximal inhibitory concentration: 3 nM
Beside the measured number, compound 4's estimate shows no gap at the digits printed; the range from low to high includes it.
By their numbers in this assay, from the lowest: compound 2; then compounds 4 and 1 (each within the scatter of the next); then compound 3.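

In this assay, among these compounds, the change from 4-aminophenyl to phenyl gives the first one-place step, a modest one: a 3.0-fold higher number from compound 2 to compound 4 (0.48 log units; beyond the scatter). The amino group is therefore not required for a low number at this position, as compound 4 still gives 3 nM without it. No evidence at hand accounts for the size of this step.

Open, from the compounds shown here alone, are other groups at this carbon, such as a hydroxyl, a methoxy or a carboxylic acid. Also open, going by these compounds, is whether an amino group on the aromatic ring would give a similar step on the core of compound 1.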